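The source may report more compounds than this note shows. Statements on the series, on what has been measured and on what is new or still open speak of the compounds shown alone.

The series brings together three compounds tested in an assay on HEK293 cells for binding affinity to 5-hydroxytryptamine receptor 7 (Homo sapiens), read by radioligand binding, tested at 1 uM; on this read-out lower numbers stand for less inhibition and higher numbers for more inhibition at the one concentration tested (going by the name of the read-out). Compound 1, `Brc1ccc2ccn(CCN3CCNCC3)c2c1`, gives 61%. Compound 2, `Brc1ccc2ccn(CCN3CCC4CCCCN4CC3)c2c1`, gives 71%. Compound 3, `CN1CCCN(CCn2ccc3ccc(C(N)=O)cc32)CC1`, gives 33%, the lowest of the three numbers: it lies well beyond the scatter under compound 1 and further still under compound 2.

The step under consideration leads from compound 3 to compound 4, `CCc1ccc2ccn(CCN3CCCN(C)CC3)c2c1`, which has not yet been measured in this assay. The change is a single one: ethyl in place of carbamoyl on an aromatic carbon. The carbamoyl group of compound 3 leaves, and an ethyl group enters at the same aromatic carbon of the shared core, while the rest of the molecule, including the seven-membered amine ring and the chain that links it to the core, stays the same.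

Among the measured compounds shown here, no measured pair in the set differs in only this one place, so the size of the step can only be estimated. Compound 3 sits so far under the other two that a move upward seems the more likely outcome, and a step of a number 22 percentage points higher from compound 3 to compound 4 (beyond the scatter) is expected, larger than the scatter but uncertain in size because compound 3 gives 33% without a close analogue. Compound 4 is therefore estimated at 55%, in a range from 30% to 80%.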

Compound 4, a percentage reported as inhibition, at one concentration (the size of the read-out at that concentration, not a potency): 66%
Compound 4: middle estimate off by 11 percentage points, on the low side; low and high end bracket the measured number.
By their numbers in this assay, from the lowest: compound 3; then compounds 1, 4 and 2 (each within the scatter of the next).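

In this assay, among the compounds shown here, ethyl in place of carbamoyl on this aromatic carbon gives a large step, a number 33 percentage points higher from compound 3 to compound 4 (beyond the scatter), the first step between two compounds that differ in only one place. With the seven-membered amine ring and its linking chain unchanged, the low number of compound 3 can now be tied to what sits at this one position of the shared core: the group that leaves carries a hydrogen-bond donor, a hydrogen-bond acceptor and a double bond outside aromatic rings, whereas the group that enters carries no donor or acceptor. The data shown offer no evidence on why the number moves with this change.

The compounds shown leave open whether this rise is particular to ethyl or would also appear with methyl, methoxy, a nitrile or a carboxylic acid on the same aromatic carbon. They also leave open whether the same exchange would give a step of similar size with a morpholine in place of the amine ring, or with a longer chain linking that ring to the core.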